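This account rests on a few compounds, and the source may have more. Where it says the series, first, only, none or still open, it means among the compounds named here.

Compounds measured in a functional assay on CHO cells for agonist activity at Alpha-1D adrenergic receptor (Homo sapiens), read by FLIPR and calcium flux; a higher number here means that more compound is needed for the effect, a lower number that less compound is needed:
Compound 1 `Cn1ccc(-c2cccc3c2CCC3c2ncc[nH]2)n1`: > 10000 nM
Compound 2 `Cc1c(OCC2=NCCN2)ccc(Cl)c1NS(C)(=O)=O`: > 10000 nM
Compound 3 `CS(=O)(=O)Nc1cccc2c1CCCC2c1ncc[nH]1`: > 10000 nM; > 10000 nM; > 10000 nM (3 entries)

In this assay compound 1 gives only a limit, > 10000 nM, not a number. Compound 2 likewise gives only a limit. Compound 3 gives only a limit in each of its three measurements. Among the compounds with values here, all values shown thus sit at the limit of > 10000 nM in this assay, at which 2 of the 3 values shown sit, so no step between measured compounds can be read from them, and compound 1 stands nowhere in particular among them.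

Compound 4 `Cn1cc(-c2cccc3c2CCC3c2ncc[nH]2)cn1` keeps the core of compound 1 and differs in one place: 1-methyl-1H-pyrazol-4-yl in place of 1-methyl-1H-pyrazol-3-yl on an aromatic carbon. Within the data shown here, with no measured step to lean on, the expected step from compound 1 to compound 4 is a step that the limit leaves unreadable from compound 1 to compound 4, meaning no change beyond the usual scatter. Compound 4 is therefore expected to give about 20000 nM, most likely within 3000 nM to 100000 nM, and probably again only a limit.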

Compound 4, half-maximal effective concentration: > 10000 nM
Compound 4: only a limit was reported; the forecaster's own chance of this, stated with the estimate: 85%; the middle value does not contradict the limit.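

Compound 1 and compound 4 each give only a limit, so no step between them can be read: the limit of > 10000 nM in this assay, at which 3 of the 4 values shown sit.

The compounds shown leave open how far apart compound 1 and compound 4 truly lie in this assay.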